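This account rests on a few compounds, and the source may have more. Where it says the series, first, only, none or still open, it means among the compounds named here.

Compound 1 `COc1ccc(CNc2ncc(C(=O)O)c3nc(-c4ccco4)nn23)cc1OC` gives 159 nM in an assay on CHO cells for displacement of a labelled ligand from adenosine receptor A3 (Homo sapiens); a lower number here means a stronger inhibitor, a higher number a weaker inhibitor.
Compound 2 `CNC(=O)c1cnc(NC(=O)NC2CCCCC2)n2nc(-c3ccco3)nc12` gives 18700 nM in this assay.
Compound 3 `CCOC(=O)c1cnc(NC2CC2)n2nc(-c3ccco3)nc12` gives 9.52 nM in this assay.

Among these three, compound 3 has the lowest number and so binds most strongly; compound 1 is the nearest to it and compound 2 the furthest, and both gaps lie beyond the usual scatter. Compound 4 `CCOC(=O)c1cnc(NC2CCCC2)n2nc(-c3ccco3)nc12` differs from compound 3 by one change: cyclopentyl in place of cyclopropyl on a nitrogen on an aromatic ring. Among the compounds with values here, no measured pair here shows this change, so the expectation rests on compound 3 alone. The step from compound 3 to compound 4 is expected to be small, a 1.3-fold higher number from compound 3 to compound 4 (0.10 log units; within the scatter), not clearly beyond the scatter in either direction. Compound 4 is therefore estimated at 12 nM in this assay, with a plausible range from 3 nM to 50 nM.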

Compound 4, inhibition constant: 35 nM
Compound 4: the middle estimate sits 2.9-fold (0.46 log units) below what was measured, and the stated range covers the measured number.
By their numbers in this assay, from the lowest: compound 3; then compound 4; then compound 1; then compound 2.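

On the nitrogen on an aromatic ring, cyclopentyl in place of cyclopropyl gives a 3.7-fold higher number from compound 3 to compound 4 (0.57 log units; beyond the scatter) in this assay. This position is therefore not indifferent to which carbon ring it carries, although this single pair shows only a modest loss of binding, not a collapse. Nothing available here says why the number rises.

On these data alone, it remains open how a cyclobutyl or cyclohexyl ring, or an open chain such as isopropyl, would fare on this nitrogen with the rest of compound 3 unchanged. A single pair also cannot show whether the same change would have a similar effect on a different core.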